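A few compounds are considered here, and "the series" means these few. Any claim that something is new, unique, unknown or untested is made for them only; others in the source may bear on it.

Compound 1 `COc1ccccc1C(=O)Nc1c[nH]nc1C(=O)N[C@H]1CC[C@H](OC)CC1`: 1500 nM
Compound 2 `COc1cccc(OC)c1C(=O)Nc1c[nH]nc1C(=O)NCc1ccccc1`: 50000 nM
Compound 3 `CO[C@H]1CC[C@H](NC(=O)c2n[nH]cc2NC(=O)c2c(C)nc3ccccn23)CC1`: 34000 nM

These three compounds were tested in an ADME assay on MRC5 cells (Homo sapiens) for inhibition, with a stated time of 72 h; a higher number here means that more compound is needed for the effect, a lower number that less compound is needed. Of the three, compound 2 has the highest number. Its nearest neighbour is compound 3, whose number is lower by an amount that stays within the usual scatter, so the two cannot be told apart on these data alone. Compound 1 lies far below compound 2, a gap well beyond the scatter, so compound 1 needs clearly less compound for the same effect.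

Compound 4 `COc1cccc(OC)c1C(=O)Nc1c[nH]nc1C(=O)Nc1ccccn1` has not yet been measured. It differs from compound 2 in one place: pyridin-2-yl in place of benzyl on an amide-type nitrogen. A benzyl group leaves and a pyridin-2-yl group enters, on an amide-type nitrogen whose other neighbour is a carbonyl carbon. Within the data shown here, no measured pair in this set shows this change, so there is no direct guide to its effect. With that in mind, the expectation for compound 4 is a step of a 1.3-fold lower number from compound 2 to compound 4 (0.10 log units; within the scatter) that stays within the scatter, in no particular direction. The estimate for compound 4 in this assay is therefore 40000 nM, with a range from 10000 nM to 150000 nM.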

Compound 4, half-maximal effective concentration: > 50000 nM
Compound 4 ended at the assay's limit; the forecaster's own chance of this, stated with the estimate: 25%; middle value at least 1.2-fold (0.09 log units) from the limit.
By their numbers in this assay, from the lowest: compound 1; then compounds 3 and 2 (each within the scatter of the next).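

In this assay compound 4 gives > 50000 nM, which is a limit of the assay and not a number. Putting pyridin-2-yl in place of benzyl on this amide-type nitrogen gives a number no lower from compound 2 to compound 4 (the limit leaves the size open), so the ring nitrogen and the hydrogen-bond acceptor counted with it bring no measurable drop in the number on this core, and that direction is the one new fact at this position. How large the step is cannot be read, because the result sits at the edge of what the assay reports: the limit of > 50000 nM in this assay, at which 1 of the 4 values shown sits.

On these data alone, whether any other group on this amide-type nitrogen, such as a longer chain ending in an amine or in a carboxylic acid, would bring the number down remains open. Also open, as far as these compounds go, is whether the same swap from benzyl to pyridin-2-yl would give the same result on a compound with a much lower starting number, where a step of this kind could be read in full.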